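The source may hold more compounds than are shown below. What is called first, only, known or untested is meant among the compounds shown, and "the series" means these compounds.

Compound 1 `CC1(COC(=O)N2CCN(c3ccc(F)cc3)CC2)CCn2cc([N+](=O)[O-])nc2O1`, compound 2 `O=[N+]([O-])c1cn2c(n1)OC(COc1ccc(-c3ccc(F)cn3)cn1)CC2` and compound 3 `CC1(COc2ccc(-c3ccc(F)cn3)cn2)CCn2cc([N+](=O)[O-])nc2O1` were all examined in an ADME assay on MRC5 cells (Homo sapiens) for cytotoxicity, read by resazurin assay, with a stated time of 72 h; on this read-out lower numbers stand for stronger inhibition and higher numbers for weaker inhibition. In this assay compound 1 reaches only > 64000 nM, which is a limit of the assay and not a number. Compound 2 in this assay likewise stops at the limit > 64000 nM. Compound 3 in this assay also gives only the limit > 64000 nM. All three therefore sit together at the limit of > 64000 nM in this assay, at which 3 of the 3 values shown sit, and no ordering among them can be drawn.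

Compound 3 and compound 2 differ in a single place, (hydrogen in place of methyl on a saturated ring carbon), and the step that the two limits leave unreadable from compound 3 to compound 2 cannot be read, since both ends are limits. The difference between the core of compound 1 and the core of compound 3 is not broken down here.

Compound 4 `O=C(OCC1CCn2cc([N+](=O)[O-])nc2O1)N1CCN(c2ccc(F)cc2)CC1` has not yet been measured. Within the data shown here, it differs from compound 1 by hydrogen in place of methyl on a saturated ring carbon, which is the same change as the one separating compound 3 from compound 2, at a place described in identical words. Because the step that the two limits leave unreadable from compound 3 to compound 2 is hidden behind two limits, the expected step is a step that the limit leaves unreadable from compound 1 to compound 4, resting on that unreadable precedent rather than on any visible trend. Compound 4 is accordingly expected to give 100000 nM in this assay, with an estimated span from 50000 nM to 300000 nM, and most probably it will be reported only as a limit once more.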

Compound 4, half-maximal inhibitory concentration: > 64000 nM
Compound 4 ended at the assay's limit; the forecaster's own chance of this, stated with the estimate: 90%; the middle value does not contradict the limit.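

Compound 1 and compound 4 both end at a limit of the assay and not at a number, so no new step can be read between them. All the compounds shown sit together in this assay: the limit of > 64000 nM in this assay, at which 4 of the 4 values shown sit. The compounds shown leave open whether hydrogen in place of methyl on a saturated ring carbon changes the read-out at all, and how any of them ranks against another.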